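Adding a Second Chloro Group to a Purine-Type Core

This account rests on a few compounds, and the source may have more. Where it says the series, first, only, none or still open, it means among the compounds named here.

Going by the values given here, compound 1 `ClCc1cccc(Cn2cnc3ncnc(Cl)c32)c1` is one of two compounds measured in a functional assay on SK-MEL-5 cells (Homo sapiens) for cytotoxicity, read by sulforhodamine B assay, with a stated time of 48 h (on this read-out higher numbers stand for weaker inhibition of growth and lower numbers for stronger inhibition of growth), and compound 1 gives 4670 nM. The other, compound 2 `ClCc1ccc(Cn2cnc3c(Cl)nc(Cl)nc32)cc1`, differs from it in two places at once and in this assay gives 6460 nM; the two numbers lie within the usual scatter of each other, so neither stands apart. Compound 3 `ClCc1cccc(Cn2cnc3nc(Cl)nc(Cl)c32)c1` has not been measured yet. It differs from compound 1 by a single change, (chloro in place of hydrogen on an aromatic carbon). Compound 2 already carries a chloro group at that same spot on the shared core and sits near compound 1 in this assay, which gives no sign that this added group moves the number much. The step from compound 1 to compound 3 is therefore expected to be small, a 1.1-fold higher number from compound 1 to compound 3 (0.03 log units; within the scatter), with no direction beyond the scatter. Compound 3 is estimated at 5000 nM, between 2000 nM and 12500 nM.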

Compound 3, concentration for 50% growth inhibition: 1200 nM
Estimate against measurement, compound 3: 4.2-fold (0.62 log units) above; measured number below the stated range.
By their numbers in this assay, from the lowest: compound 3; then compounds 1 and 2 (each within the scatter of the next).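

On this assay, putting chloro in place of hydrogen on this aromatic carbon, between two ring nitrogen atoms, gives a 3.9-fold lower number from compound 1 to compound 3 (0.59 log units; beyond the scatter), a modest step that means stronger inhibition of growth. The earlier pair differed in two places at once, so it could not isolate this position; this single change shows that the position is not silent and that one added chlorine atom is enough to shift the number beyond the scatter. Nothing available here explains the step. Whether chloro is special at this spot stays open, as the compounds shown do not tell how an amine, a methoxy group or a bromo group would behave there. Also open, on these data alone, is whether the same step would appear on other cell lines.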